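Lengthening the Chain on a Weak Antiproliferative Sulfonate

The source may hold more compounds than are shown below. What is called first, only, known or untested is meant among the compounds shown, and "the series" means these compounds.

Compound 1 `CCCN1CCN(c2ccc(S(=O)(=O)Oc3cccc(F)c3)cc2)C1=O` carries a propyl chain on the ring nitrogen of its shared core. In a functional assay on HT-29 cells (Homo sapiens) for antiproliferative activity, read by sulforhodamine B assay, with a stated time of 48 h (a lower number here means a stronger inhibitor, a higher number a weaker inhibitor), compound 1 gives 18000 nM. Its measured neighbour, compound 2 `CCCN1CCN(c2ccc(S(=O)(=O)Oc3ccc(F)cc3)cc2)C1=O`, differs only in where the fluorine sits on the phenyl ring, and in this assay compound 2 gives 23000 nM. The step between them is a 1.3-fold higher number from compound 1 to compound 2 (0.11 log units; within the scatter), so compound 1 is one of two measured compounds whose numbers sit within the scatter of each other; neither can be called the stronger inhibitor.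

Compound 3 `CCCCN1CCN(c2ccc(S(=O)(=O)Oc3cccc(F)c3)cc2)C1=O` is reached from compound 1 by the change (methyl in place of hydrogen on a saturated chain carbon, three bonds along the chain from an amide-type nitrogen in a ring). Among the compounds with values here, no measured step bears on this change: the only step in hand, from compound 1 to compound 2, concerns the fluorophenyl rather than the chain, and it lies within the scatter. With nothing to point either way, the expected step is none beyond the scatter, no change at the digits printed from compound 1 to compound 3 (within the scatter). Compound 3 is therefore estimated at 18000 nM in this assay, with a range from 7000 nM to 45000 nM.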

Compound 3, half-maximal inhibitory concentration: 76000 nM
For compound 3 the middle estimate is 4.2-fold (0.63 log units) below the measured one; the whole stated range lies below it.
By their numbers in this assay, from the lowest: compounds 1 and 2 (each within the scatter of the next); then compound 3.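

Adding a methyl on a saturated chain carbon, three bonds along the chain from an amide-type nitrogen in a ring, turns propyl into butyl, and in this assay the result is a 4.2-fold higher number from compound 1 to compound 3 (0.63 log units; beyond the scatter). This shows that the chain position is sensitive to a small extension, with the longer chain giving the weaker inhibitor, whereas moving the fluorine on the phenyl ring gave no difference that could be told from the scatter. No measurement in hand explains why butyl gives the higher number.

On these data alone, one modest step from a single pair cannot show how the number depends on chain length, so it remains open whether ethyl, pentyl or a longer chain would continue this direction, or whether a chain ending in an amine or a carboxylic acid would behave differently. As far as these compounds go, whether the same step from propyl to butyl holds with the 4-fluorophenyl group of compound 2 also remains open.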